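Biphenyl ether acids: 3-fluorophenoxy in place of trifluoromethoxy

The source may report more compounds than this note shows. Statements on the series, on what has been measured and on what is new or still open speak of the compounds shown alone.

Values in a functional assay on isolated protein for agonist activity at Free fatty acid receptor 1 (Homo sapiens), read by HTRF and inositol phosphate accumulation, with a stated time of 60 min; on this read-out lower numbers stand for an effect already at smaller amounts and higher numbers for an effect only at larger amounts of compound:
- compound 1 `CCOc1ccc(Cl)c(-c2ccc(OCCCC(=O)O)cc2)c1`: 1130 nM
- compound 2 `O=C(O)CCCOc1ccc(-c2cc(OC(F)(F)F)ccc2F)cc1`: 4220 nM
- compound 3 `O=C(O)CCCOc1ccc(-c2ccccc2C(F)(F)F)cc1`: > 9950 nM, a limit of the assay, not a number the limit of > 9950 nM in this assay, at which 1 of the 3 values shown sits.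

Of the two numbers shown, compound 2 sits at the higher one; the gap to compound 1 lies beyond the scatter. Compound 3 sits at a limit of the assay only. The series shares the butanoic acid ether chain on a biphenyl core and varies the substituents on the second ring.

Compound 4 `O=C(O)CCCOc1ccc(-c2cc(Oc3cccc(F)c3)ccc2F)cc1` differs from compound 2 in one place: 3-fluorophenyl in place of trifluoromethyl on an oxygen on an aromatic ring. For the measured compounds named here, no pair of measured compounds covers a change of this kind, so the expected direction rests on compound 2 alone, with the other two compounds giving no guide. For compound 4 a modest gain in this assay is expected, a 2.8-fold lower number from compound 2 to compound 4 (0.45 log units; beyond the scatter), with wide uncertainty in both directions. Compound 4 is estimated at 1500 nM, with a range from 400 nM to 6000 nM.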

Compound 4, half-maximal effective concentration: 9460 nM
Compound 4: the middle estimate sits 6.3-fold (0.80 log units) below what was measured, outside the stated range (above it).
By their numbers in this assay, from the lowest: compound 1; then compound 2; then compound 4. At a limit, above all of these: compound 3.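

On an oxygen on an aromatic ring, the change from trifluoromethoxy to 3-fluorophenoxy gives a 2.2-fold higher number from compound 2 to compound 4 (0.35 log units; beyond the scatter) in this assay. For the compounds shown here, this is the first single-place comparison, and it shows that placing a six-membered aromatic ring of carbon only on this oxygen brings no gain here, though the reading rests on one pair. Compound 3 remains the only compound held at a limit of the assay: the limit of > 9950 nM in this assay, at which 1 of the 4 values shown sits.

Going by these compounds, it remains open whether the higher number goes with the ring itself or with its fluorine, which a plain phenyl on the same oxygen would separate. A methyl or a short amine-bearing chain at this oxygen would show whether the trend extends beyond these two groups.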